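This account rests on a few compounds, and the source may have more. Where it says the series, first, only, none or still open, it means among the compounds named here.

Within the data shown here, compound 1 `Cc1ccc2[nH]c(-c3ccc(-c4ccc(-c5ccc(N(C)C)cc5)cc4)cc3)nc2c1` gives the lowest of the two numbers so far in a functional assay on A549 cells (Homo sapiens) for inhibition, read by sulforhodamine B assay; on this read-out higher numbers stand for weaker inhibition of growth and lower numbers for stronger inhibition of growth: compound 1 gives 3510 nM, whereas compound 2 `CN(C)c1ccc(-c2ccc(-c3ccc(-c4nc5ccccc5[nH]4)cc3)cc2)cc1` gives 30100 nM, the step of an 8.6-fold higher number from compound 1 to compound 2 (0.93 log units; beyond the scatter) being the only measured step in the set. Compound 3 `Cc1ccc2[nH]c(-c3ccc(-c4ccc(-c5ccc(C(F)(F)F)cc5)cc4)cc3)nc2c1` is not yet measured; it differs from compound 1 by trifluoromethyl in place of dimethylamino on an aromatic carbon. Among the measured compounds shown here, no measured step bears on this change: the single available step, from compound 1 to compound 2, concerns the methyl on the shared core and leaves the dimethylamino untouched, so it says nothing about the 4-(dimethylamino)phenyl to 4-(trifluoromethyl)phenyl exchange. For the measured compounds named here, with no comparable step in hand, the expectation for compound 3 rests on compound 1 alone and is set near it, as an expected step of a 1.4-fold higher number from compound 1 to compound 3 (0.15 log units; within the scatter) with a wide range on either side. Compound 3 is estimated at 5000 nM in this assay, expected to fall between 1200 nM and 25000 nM.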

Compound 3, concentration for 50% growth inhibition: 3520 nM
Estimate against measurement, compound 3: 1.4-fold (0.15 log units) above; the range from low to high includes it.
By their numbers in this assay, from the lowest: compounds 1 and 3 (each within the scatter of the next); then compound 2.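

In this assay, trifluoromethyl in place of dimethylamino on this aromatic carbon, para to a large group, gives a 1.0-fold higher number from compound 1 to compound 3 (0.00 log units; within the scatter), so the two groups cannot be told apart on this read-out. Among these compounds, the level of compound 1 therefore does not depend on keeping the 4-(dimethylamino)phenyl end, and the only step beyond the scatter remains the one at the methyl on the shared core, an 8.6-fold higher number from compound 1 to compound 2 (0.93 log units; beyond the scatter). Nothing available explains why the two groups read alike.

The compounds shown leave open whether a carboxylic acid or a longer alkyl chain on this aromatic carbon would stay at the same level. They also leave open whether trifluoromethyl and dimethylamino would still match on the core of compound 2, which lacks the methyl.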